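A few compounds are considered here, and "the series" means these few. Any claim that something is new, unique, unknown or untested is made for them only; others in the source may bear on it.

Of the compounds shown here, three of one family have been measured in a functional assay on SNB-75 cells (Homo sapiens) for inhibition, read by sulforhodamine B assay, with a stated time of 48 h; a lower number here means a stronger inhibitor of growth, a higher number a weaker inhibitor of growth. Compound 1 `COc1ccc(-c2[nH]c3ccccc3c2/C=C(\C#N)S(=O)(=O)c2ccccc2)cc1` gives 379 nM in this assay. Compound 2 `O=C(/C(=C\c1c(-c2ccccc2)[nH]c2ccccc12)S(=O)(=O)c1ccccc1)c1ccccc1` carries a benzoyl group in place of the nitrile of compound 1; in this assay compound 2 gives 10100 nM. Compound 3 `COc1ccc2[nH]c(-c3ccccc3)c(/C=C(\C#N)S(=O)(=O)c3ccccc3)c2c1` gives 5900 nM in this assay, the second highest of the three numbers; its value and that of compound 2 lie within the scatter of each other, while compound 1 sits well lower, beyond the scatter.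

The step considered here leads from compound 3 to compound 4 `N#C/C(=C\c1c(-c2ccccc2)[nH]c2ccccc12)S(=O)(=O)c1ccccc1`. The change is hydrogen in place of methoxy on an aromatic carbon, so compound 4 is the parent without any methoxy group at all. Going by the values given here, no measured pair shows this exact change, so the step cannot be read off the data. Compound 1, whose only methoxy sits on the pendant phenyl, gives 379 nM, suggesting that the core without the methoxy on the fused ring can reach lower numbers. Compound 4 is therefore expected to show a modest move downward, estimated as a 3.0-fold lower number from compound 3 to compound 4 (0.47 log units; beyond the scatter). The expected value of compound 4 in this assay is 2000 nM, within a range from 600 nM to 8000 nM.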

Compound 4, concentration for 50% growth inhibition: 1700 nM
Estimate against measurement, compound 4: 1.2-fold (0.07 log units) above; measured number inside the range.
By their numbers in this assay, from the lowest: compound 1; then compound 4; then compounds 3 and 2 (each within the scatter of the next).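

In this assay, hydrogen in place of methoxy gives a 3.5-fold lower number from compound 3 to compound 4 (0.54 log units; beyond the scatter) where the methoxy stands on the fused system of two rings, but a 4.5-fold higher number from compound 1 to compound 4 (0.65 log units; beyond the scatter) where it stands elsewhere, so the same change runs in opposite directions depending on its place. Going by these compounds alone, with compound 4 the nitrile and benzoyl groups can also be compared directly for the first time: cyano in place of benzoyl gives a 5.9-fold lower number from compound 2 to compound 4 (0.77 log units; beyond the scatter). Nothing shown explains either the opposite directions or the effect of the nitrile.

Going by these compounds, it remains open whether a hydroxy group, a fluorine atom or an amine on that aromatic carbon would give a number like that of compound 3 or compound 4. Also open, on these data alone, is how an ester or an amide would compare with the nitrile.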